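Adding fluorines to a ring at the assay limit

The compounds below may be only part of what the source reports. "The series", "measured", "known", "first", "only" and "open" are said of these compounds alone.

In a functional assay with Homo sapiens as the target (on this read-out lower numbers stand for stronger inhibition and higher numbers for weaker inhibition), compound 3 `CC(C)[C@H](NC(=O)COc1cccc2ccccc12)C(=O)N[C@@H](CC(=O)O)C(=O)COc1c(F)cccc1F` gives > 100000 nM as its result, which is a limit and not a number. Two close relatives read lower in this assay, where compound 1 `CC(C)[C@H](NC(=O)COc1cccc2ccccc12)C(=O)N[C@@H](CC(=O)O)C(=O)COC(=O)c1c(Cl)cccc1Cl` gives 11500 nM and compound 2 `CC(C)[C@H](NC(=O)COc1cccc2ccccc12)C(=O)N[C@@H](CC(=O)O)C(=O)COc1ccccc1[N+](=O)[O-]` gives 27700 nM on the same scale.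

Compound 4 `CC(C)[C@H](NC(=O)COc1cccc2ccccc12)C(=O)N[C@@H](CC(=O)O)C(=O)COc1c(F)c(F)cc(F)c1F` differs from compound 3 only in the ring on the oxygen, as 2,3,5,6-tetrafluorophenyl in place of 2,6-difluorophenyl on an oxygen on a saturated carbon shows, with 2,3,5,6-tetrafluorophenyl in place of 2,6-difluorophenyl.

Within the data shown here, no measured step makes this exact swap. The nearest evidence shows that the group on this oxygen can move the number: 2,6-difluorophenyl replacing 2-nitrophenyl gave an at least 3.6-fold higher number from compound 2 to compound 3 (0.55 log units; beyond the scatter) overall, and replacing (2,6-dichlorophenyl)carbonyl gave an at least 8.6-fold higher number from compound 1 to compound 3 (0.93 log units; beyond the scatter) overall. The remaining pair shows a 2.4-fold higher number from compound 1 to compound 2 (0.38 log units; beyond the scatter) as its gap.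

Steps of that size suggest a modest drop, expected as an at least 2.5-fold lower number from compound 3 to compound 4 (0.39 log units; beyond the scatter) in this assay, though a result still at the limit remains possible. Compound 4 is estimated at 40000 nM in this assay, with an expected range from 8000 nM to 150000 nM around that figure.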

Compound 4, half-maximal inhibitory concentration: 6250 nM
The estimate for compound 4 lay 6.4-fold (0.81 log units) above the measured number, and the stated range ends above it.
By their numbers in this assay, from the lowest: compounds 4 and 1 (each within the scatter of the next); then compound 2. At a limit, above all of these: compound 3.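

Within a single ring type, moving from 2,6-difluorophenyl to 2,3,5,6-tetrafluorophenyl gave an at least 16-fold lower number from compound 3 to compound 4 (1.20 log units; beyond the scatter) in this assay, so the fluorine pattern on this ring matters, and not only the kind of group on the oxygen. The new ring also gave a 4.4-fold lower number from compound 2 to compound 4 (0.65 log units; beyond the scatter), while a 1.8-fold lower number from compound 1 to compound 4 (0.26 log units; within the scatter) leaves the two compounds level, which shows that a phenyl ring on this oxygen can match the (2,6-dichlorophenyl)carbonyl group, although compound 2 and compound 3 do not. Compound 3 stands at a limit and not at a number, so the step from it gives only a minimum size: the limit of > 100000 nM in this assay, at which 1 of the 4 values shown sits.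

As far as these compounds go, whether the count of fluorines or their places on the ring drives this change remains open. Also open, from the compounds shown here alone, is how an amine or a methoxy group on this ring would read, or a longer chain in place of the ring.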